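Aryl Swap on the Piperidine Amide Series

The source may report more compounds than this note shows. Statements on the series, on what has been measured and on what is new or still open speak of the compounds shown alone.

Measured so far: compound 1 `CCOC(=O)C1(C)Oc2ccc(NC(=O)C3CCN(c4cc(F)c(F)c(F)c4)CC3)cc2NC1=O` with 870 nM in a functional assay for antagonist activity at transient receptor potential cation channel subfamily V member 1 (Homo sapiens), read by FLIPR and calcium flux; on this read-out lower numbers stand for stronger inhibition and higher numbers for weaker inhibition; compound 2 `O=C(Nc1ccc2cc[nH]c2c1)C1CCN(c2cccc(C(F)(F)F)c2)CC1`, > 9000 nM in this assay, a limit; compound 3 `Cc1ccccc1N1CCC(C(=O)Nc2ccc3c(c2)NC(=O)CO3)CC1`, 150 nM in this assay.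

Compound 3 stands lowest of the two numbers; the nearest is compound 1, whose value sits well beyond the scatter above it. Compound 2 reports only a limit, (the limit of > 9000 nM in this assay, at which 1 of the 3 values shown sits).

Compound 4 `O=C1COc2ccc(NC(=O)C3CCN(c4cc(F)c(F)c(F)c4)CC3)cc2N1` differs from compound 3 by 3,4,5-trifluorophenyl in place of 2-methylphenyl on an amine nitrogen in a ring. Compound 1 carries the same 3,4,5-trifluorophenyl on its own core and gives 870 nM in this assay, a weaker value than compound 3. A modest weakening, probably beyond the scatter, is expected in this assay, as a 2.7-fold higher number from compound 3 to compound 4 (0.43 log units; beyond the scatter). Compound 4 is estimated at 400 nM, between 120 nM and 1500 nM.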

Compound 4, half-maximal inhibitory concentration: 59 nM
Compound 4: middle estimate off by 6.8-fold (0.83 log units), on the high side; the measured number lies below the stated range.
By their numbers in this assay, from the lowest: compound 4; then compound 3; then compound 1. At a limit, above all of these: compound 2.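

On the amine nitrogen in a ring, 3,4,5-trifluorophenyl in place of 2-methylphenyl gives in this assay a 2.5-fold lower number from compound 3 to compound 4 (0.41 log units; beyond the scatter). For the compounds shown here, this is the first pair with two aryl groups on one shared core, so it shows that the aryl group at this position alone moves the number, and that the trifluorinated ring is the better of the two here. Nothing measured here gives a cause for this step.

On these data alone, it remains open whether a phenyl ring bearing a single fluorine or a chlorine would do the same on this core. As far as these compounds go, whether the same swap holds on the core of compound 1 also stays open.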